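The source may report more compounds than this note shows. Statements on the series, on what has been measured and on what is new or still open speak of the compounds shown alone.

For the measured compounds named here, in a functional assay on KYSE-450 cells (Homo sapiens) for inhibition, read by MTT assay, with a stated time of 48 h (a lower number here means a stronger inhibitor, a higher number a weaker inhibitor), compound 1 `COc1ccc(CN(C(=O)C(C)Br)c2cc(OC)c(OC)c(OC)c2)cc1O` gives 160 nM, the lowest of the two numbers measured so far. Compound 2 `COc1ccc(CNc2cc(OC)c(OC)c(OC)c2)cc1Br` gives 39800 nM in this assay, a far higher number, well beyond the usual scatter. Going by the values given here, compound 3 `COc1ccc(CN(C(=O)CCCCCl)c2cc(OC)c(OC)c(OC)c2)cc1O` has not been measured. 4-chlorobutyl in place of 1-bromoethyl on a carbonyl carbon No measured pair shows this change, so its effect rests on expectation alone. The expected step is a 4.4-fold higher number from compound 1 to compound 3 (0.64 log units; beyond the scatter), a move toward a higher number that exceeds the scatter. In this assay compound 3 is estimated at 700 nM, within a range from 150 nM to 4000 nM.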

Compound 3, half-maximal inhibitory concentration: 770 nM
Compound 3: middle estimate off by 1.1-fold (0.04 log units), on the low side; the range from low to high includes it.
By their numbers in this assay, from the lowest: compound 1; then compound 3; then compound 2.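

In this assay, for the compounds shown here, putting 4-chlorobutyl in place of 1-bromoethyl on this carbonyl carbon gives a 4.8-fold higher number from compound 1 to compound 3 (0.68 log units; beyond the scatter), the first direct reading of this position: the group there matters, yet this larger chain costs only a modest step. The swap changes the halogen and the chain together, so the step cannot be divided between them. Nothing available explains the shift.

A 4-bromobutyl or 1-chloroethyl group would separate those two changes. Going by these compounds, whether the halogen is needed at all remains open, as does how a plain butyl chain or a chain ending in an amine would compare.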